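The source may report more compounds than this note shows. Statements on the series, on what has been measured and on what is new or still open speak of the compounds shown alone.

Measured compounds: compound 1 `CCCCCC(=O)c1ccc(CN(CCCCCCC(=O)O)S(C)(=O)=O)cc1` gives 887 nM in a functional assay on HEK293 cells for agonist activity at prostaglandin E2 receptor EP2 subtype (Rattus norvegicus), read by cAMP accumulation; a lower number here means that less compound is needed, a higher number that more compound is needed for the effect; compound 2 `CCCCC(O)c1ccc(CN(CCCCCCC(=O)O)S(C)(=O)=O)cc1` gives 423 nM.

Compound 2 has the lowest of the two numbers; its nearest neighbour is compound 1, a step of a 2.1-fold lower number from compound 1 to compound 2 (0.32 log units; beyond the scatter). Compound 3 `CS(=O)(=O)N(CCCCCCC(=O)O)Cc1ccc(-c2ccccc2)cc1` differs from compound 2 by phenyl in place of 1-hydroxypentyl on an aromatic carbon. Going by the values given here, the only measured step, a 2.1-fold lower number from compound 1 to compound 2 (0.32 log units; beyond the scatter), exchanges a carbonyl for a hydroxyl and so bears only loosely on a change that removes the hydroxyl and the chain together. A small step in this assay is therefore expected for compound 3, most likely toward a higher number, estimated as 700 nM (range 200 nM to 2500 nM), a step of a 1.7-fold higher number from compound 2 to compound 3 (0.22 log units; within the scatter).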

Compound 3, half-maximal effective concentration: 457 nM
Beside the measured number, compound 3's estimate is 1.5-fold (0.19 log units) above it; measured number inside the range.
By their numbers in this assay, from the lowest: compounds 2, 3 and 1 (each within the scatter of the next, the first and the last beyond it).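

At this aromatic carbon, phenyl and 1-hydroxypentyl cannot be told apart in this assay, with a 1.1-fold higher number from compound 2 to compound 3 (0.03 log units; within the scatter) lying within the scatter. Phenyl also stays within the scatter of pentylcarbonyl, with a 1.9-fold lower number from compound 1 to compound 3 (0.29 log units; within the scatter) as the step, so an aromatic ring with no hydroxyl can stand here without a reading separate from either chain. Nothing given here explains this likeness.

On these data alone, whether a plain pentyl chain at this carbon would read like these groups stays open. So does the effect of an amine or a carboxylic acid on the phenyl ring.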